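Sulfamoyl in place of the hydroxy group on compound 3

A few compounds are considered here, and "the series" means these few. Any claim that something is new, unique, unknown or untested is made for them only; others in the source may bear on it.

In an ADME assay (liver) for metabolic stability, with Liver microsome (Rattus norvegicus) as the target, using microsomes and NADPH, with a stated time of 30 min, at 37 degrees C, tested at 1 uM (a lower number here means slower removal, a higher number faster removal of the compound), compound 1 (`CC#Cc1cc(C(O)(C(F)(F)F)C(F)(F)F)cnc1-c1ccc(S(=O)(=O)c2ccc(N)nc2)cc1`) gives 177 mL.min-1.g-1 as a measured number, and compound 2 (`CC(O)(c1ccc(-c2ccc(S(=O)(=O)c3ccc(N)nc3)nc2Nc2cccnc2)nc1)C(F)(F)F`) gives 142 mL.min-1.g-1 as a measured number. Compound 3 (`CC(O)(c1ccc(-c2ncc(S(=O)(=O)c3ccc(N)nc3)s2)c(Cl)c1)C(F)(F)F`) gives < 14 mL.min-1.g-1 here, which is a limit of the assay and not a number. Compound 3 thus stands at the limit of < 14 mL.min-1.g-1 in this assay, at which 1 of the 3 values shown sits, and lies well on the slow side of the other two compounds.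

Compound 4 (`Nc1ccc(S(=O)(=O)c2cnc(-c3ccc(S(N)(=O)=O)cc3Cl)s2)cn1`) carries sulfamoyl in place of 1-hydroxy-1-(trifluoromethyl)ethyl on an aromatic carbon, meta to a chloro group and para to a large group (sulfamoyl in place of 1-hydroxy-1-(trifluoromethyl)ethyl on an aromatic carbon). Within the data shown here, no measured pair isolates this change. The expectation therefore rests only on the limit of compound 3 at < 14 mL.min-1.g-1 and nothing more. A small step in this assay is expected, with no firm direction and nothing beyond the usual scatter. The estimated change is a step that the limit leaves unreadable from compound 3 to compound 4 and is expected to stay that small. Compound 4 is estimated at 12 mL.min-1.g-1, with an expected range from 6 mL.min-1.g-1 to 30 mL.min-1.g-1 and a good chance of only a limit being reported.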

Compound 4, intrinsic clearance in microsomes: 107 mL.min-1.g-1
Compound 4: middle estimate off by 8.9-fold (0.95 log units), on the low side; measured number above the stated range.
By their numbers in this assay, from the lowest: compounds 4, 2 and 1 (each within the scatter of the next). At a limit, below all of these: compound 3.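

Sulfamoyl in place of 1-hydroxy-1-(trifluoromethyl)ethyl, on an aromatic carbon meta to a chloro group, gives an at least 7.6-fold higher number from compound 3 to compound 4 (0.88 log units; beyond the scatter) in this assay. Among these compounds, this is the first single-place change, and it shows that the group held at this position alone can move the read-out beyond the scatter, which compound 1 and compound 2 could not show. The true size of the step remains unknown, as the value of compound 3 is a limit of the assay and not a number: the limit of < 14 mL.min-1.g-1 in this assay, at which 1 of the 4 values shown sits.

The compounds shown hold only these two groups at this position, so it remains open whether an amine or a carboxylic acid here would give a number nearer that of compound 3 or that of compound 4. On these data alone, whether the same exchange acts alike on the core of compound 1 or of compound 2 also stays open.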